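Amide Aryl Exchange and the Expected Cytotoxicity Limit

This account rests on a few compounds, and the source may have more. Where it says the series, first, only, none or still open, it means among the compounds named here.

Compound 1, `COc1ccccc1NC(=O)c1ccc2cccc(O)c2n1`: in an ADME assay on THP-1 cells (Homo sapiens) for cytotoxicity, read by WST assay, with a stated time of 24 h (a lower number here means a stronger inhibitor, a higher number a weaker inhibitor), compound 1 reaches only the limit > 30000 nM.
Compound 2, `COc1cccc(NC(=O)c2ccc3cccc(O)c3n2)c1`: in this assay compound 2 also reaches only the limit > 30000 nM.
Compound 3, `Cc1ccccc1NC(=O)c1ccc2cccc(O)c2n1`: in this assay compound 3 likewise gives the limit > 30000 nM.

Compound 3 therefore stands at the limit of this assay, and the two further values shown are limits as well; none of the three is a number. For the measured compounds named here, the one step that connects measured compounds, a step that the two limits leave unreadable from compound 1 to compound 3, cannot be read for size because both ends sit at a limit. All that the measured data establish is the limit of > 30000 nM in this assay, at which 3 of the 3 values shown sit.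

Compound 4, `O=C(Nc1cccc(F)c1)c1ccc2cccc(O)c2n1`, has not been measured in this assay. It differs from compound 3 in one place: 3-fluorophenyl in place of 2-methylphenyl on an amide-type nitrogen. Going by the values given here, no measured step covers an exchange of this kind, and the only related step, from compound 1 to compound 3, gives no readable size, so there is nothing in the numbers to predict a change in either direction beyond the scatter. On this basis compound 4 is expected to stay at the limit too, with a number no higher from compound 3 to compound 4 (the limit leaves the size open) as the implied step. The estimate for compound 4 in this assay is 30000 nM, in the range 15000 nM to 60000 nM.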

Compound 4, half-maximal inhibitory concentration: > 30000 nM
Compound 4: a limit, no number (the forecaster's own chance of this, stated with the estimate: 85%); the middle value sits exactly at the limit.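

In this assay compound 4 also gives only a limit, > 30000 nM, and not a number. Neither step into compound 4, from compound 3 or from compound 2, can be read for size. The compounds shown leave open whether these aryl groups on the amide differ at all in cytotoxicity, with the data holding only this: the limit of > 30000 nM in this assay, at which 4 of the 4 values shown sit.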